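Aryl swap on the triazole nitrogen: outlook for compound 3

This account rests on a few compounds, and the source may have more. Where it says the series, first, only, none or still open, it means among the compounds named here.

Compound 2 `N#CC1=C(N)Oc2c(N)cc3nc4ccccc4nc3c2C12C(=O)N(Cc1cnnn1-c1ccc([N+](=O)[O-])cc1[N+](=O)[O-])c1ccccc12` is known in a functional assay on A549 cells (Homo sapiens) for antiproliferative activity, read by MTT assay, with a stated time of 48 h (on this read-out lower numbers stand for stronger inhibition and higher numbers for weaker inhibition), only as a limit, > 50000 nM, the limit (the limit of > 50000 nM in this assay, at which 1 of the 2 values shown sits). In this assay compound 1 `Cc1ccc(-n2nncc2CN2C(=O)C3(C(C#N)=C(N)Oc4c(N)cc5nc6ccccc6nc5c43)c3ccccc32)cc1Cl` gives 11800 nM. Among the measured compounds shown here, the single measured step, an at least 4.2-fold higher number from compound 1 to compound 2 (0.62 log units; beyond the scatter), is the one that bears here, and it runs toward compound 2. Compound 3 `COc1cc(-n2nncc2CN2C(=O)C3(C(C#N)=C(N)Oc4c(N)cc5nc6ccccc6nc5c43)c3ccccc32)c(OC)cc1Cl` differs from compound 2 by 4-chloro-2,5-dimethoxyphenyl in place of 2,4-dinitrophenyl on an aromatic nitrogen, which returns a chloro-bearing aryl like that of compound 1. A step of about the same size in the opposite direction is therefore expected for compound 3, an at least 3.3-fold lower number from compound 2 to compound 3 (0.52 log units; beyond the scatter) in this assay. For compound 3 the estimate is 15000 nM, between 5000 nM and 50000 nM.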

Compound 3, half-maximal inhibitory concentration: > 50000 nM
Compound 3: only a limit was reported (the forecaster's own chance of this, stated with the estimate: 30%); middle value at least 3.3-fold (0.52 log units) from the limit.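

In this assay, a chlorine on the aryl group does not by itself hold the activity at this position: 4-chloro-2,5-dimethoxyphenyl in place of 3-chloro-4-methylphenyl gives an at least 4.2-fold higher number from compound 1 to compound 3 (0.62 log units; beyond the scatter). Of the three aryl groups shown, only the 3-chloro-4-methylphenyl of compound 1 gives a number rather than a limit. The step between compound 2 and compound 3 cannot be read, as both are limits: the limit of > 50000 nM in this assay, at which 2 of the 3 values shown sit.

Open, on these data alone, is whether an unsubstituted phenyl or a 4-aminophenyl on this nitrogen would give a measurable value, and which of the chloro and methyl groups of compound 1 matters.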